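Swapping Dichlorophenyl for Aminophenyl on the Sulfonyl Sulfur

The compounds below may be only part of what the source reports. "The series", "measured", "known", "first", "only" and "open" are said of these compounds alone.

Within the data shown here, compound 3 `CC1CCN(C2CCN(S(=O)(=O)c3ccc(Cl)c(Cl)c3)CC2)CC1` is the only member of the set with a measured number: in a functional assay on DLD-1 cells (Homo sapiens) for antiproliferative activity, read by CellTiter-Glo, with a stated time of 72 h (a higher number here means a weaker inhibitor, a lower number a stronger inhibitor), compound 3 gives 2.9 nM. Compound 1 `CC1CCN(C2CCN(S(=O)(=O)c3cn(C)cn3)CC2)CC1` yields only an assay limit, > 5000 nM in this assay. Compound 2 `CC1CCN(C2CCN(S(=O)(=O)c3cccnc3Cl)CC2)CC1` likewise yields only a limit, > 5000 nM in this assay. Both steps onto compound 3 are large, an at least 1700-fold lower number from compound 1 to compound 3 (3.23 log units; beyond the scatter) and an at least 1700-fold lower number from compound 2 to compound 3 (3.23 log units; beyond the scatter), although each starts from the limit of > 5000 nM in this assay, at which 2 of the 3 values shown sit, and its true size is unreadable. Compound 4 `CC1CCN(C2CCN(S(=O)(=O)c3cccc(N)c3)CC2)CC1` differs from compound 3 by 3-aminophenyl in place of 3,4-dichlorophenyl on a sulfonyl sulfur. Among the measured compounds shown here, no measured step exchanges the 3,4-dichlorophenyl for another phenyl, so the change is judged only from the large gains the dichlorophenyl gave. A loss beyond the scatter is expected, a 170-fold higher number from compound 3 to compound 4 (2.24 log units; beyond the scatter). Compound 4 is therefore estimated at 500 nM, between 50 nM and 5000 nM in this assay.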

Compound 4, half-maximal inhibitory concentration: 3400 nM
Beside the measured number, compound 4's estimate is 6.8-fold (0.83 log units) below it; low and high end bracket the measured number.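

Keeping a six-membered aromatic ring of carbon only on the sulfonyl sulfur does not preserve activity in this assay: a 1200-fold higher number from compound 3 to compound 4 (3.07 log units; beyond the scatter). The potency of compound 3 therefore depends on more than a phenyl ring at this position. The steps of an at least 1.4-fold lower number from compound 2 to compound 4 (0.16 log units; that floor lies within the scatter) and an at least 1.4-fold lower number from compound 1 to compound 4 (0.16 log units; that floor lies within the scatter) give only floors within the scatter, and their true size is unreadable: the limit of > 5000 nM in this assay, at which 2 of the 4 values shown sit.

As far as these compounds go, it remains open whether a phenyl with one chlorine would hold the activity of compound 3. From the compounds shown here alone, it also remains open whether the drop follows from the loss of the chlorines or the arrival of the amine.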